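The source may hold more compounds than are shown below. What is called first, only, known or untested is meant among the compounds shown, and "the series" means these compounds.

Measured compounds:
compound 1, `COC(=O)c1cccc(CSc2ccc3c(C)cc(=O)oc3c2)c1`: 14100 nM
compound 2, `CCc1oc2c(C)c(OC)ccc2c(=O)c1Br`: > 33600 nM

In a functional assay on DU-145 cells (Homo sapiens) for antiproliferative activity, read by sulforhodamine B assay, with a stated time of 72 h (on this read-out lower numbers stand for stronger inhibition of growth and higher numbers for weaker inhibition of growth), compound 1 gives 14100 nM. For compound 2 the read-out of this assay is only a limit, > 33600 nM, not a number. Compound 2 thus sits at the limit of > 33600 nM in this assay, at which 1 of the 2 values shown sits, so its place relative to compound 1 cannot be fixed more closely than that.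

The step to compound 3, `CCc1oc2c(C)c(OCc3ccccc3)ccc2c(=O)c1Br`, is phenyl in place of hydrogen on a saturated chain carbon bound to an oxygen on an aromatic ring. Among the compounds with values here, no measured pair shows this change, so the size of the step in this assay is unknown; with compound 2 itself only a limit, the direction is open, and a step beyond the scatter either way cannot be ruled out.

Compound 3 is expected to stay weak in this assay, with an estimated 30000 nM (range 8000 nM to 100000 nM). This estimate means an expected step of an at least 1.1-fold lower number from compound 2 to compound 3 (0.04 log units; that floor lies within the scatter), set against a limit rather than a number.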

Compound 3, concentration for 50% growth inhibition: > 26700 nM
Compound 3: a limit, no number (the forecaster's own chance of this, stated with the estimate: 55%); the middle value lies beyond the limit too.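

In this assay, within the data shown here, compound 2 and compound 3 both give only limits, not numbers, so no step between them can be read. The compounds shown leave open how strongly either inhibits growth, and whether phenyl in place of hydrogen changes the read-out at all.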